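The source may report more compounds than this note shows. Statements on the series, on what has been measured and on what is new or still open speak of the compounds shown alone.

Compound 1 `CCO/C(O)=C1\C(COCCNC(=O)c2cnccn2)=NC(C)=C(C(=O)OC)C1c1ccccc1Cl` gives 39.8 nM in a functional assay (aorta) with Rattus norvegicus as the target; a lower number here means a stronger inhibitor, a higher number a weaker inhibitor. Compound 2 `CCO/C(O)=C1\C(COCCN(C)C(=O)NC)=NC(C)=C(C(=O)OC)C1c1ccccc1Cl` gives 20 nM in this assay.

Compound 2 has the lower of the two numbers, yet the gap a 2.0-fold lower number from compound 1 to compound 2 (0.30 log units; within the scatter) lies within the scatter, so the two cannot be ranked. Compound 3 `CCO/C(O)=C1\C(COCCNCC(=O)NC)=NC(C)=C(C(=O)OC)C1c1ccccc1Cl` is still to be measured; it differs from compound 2 by ((methylcarbamoyl)methyl)amino in place of methyl(methylcarbamoyl)amino on a saturated chain carbon, two bonds along the chain from an oxygen on a saturated carbon. Going by the values given here, the only measured step, a 2.0-fold lower number from compound 1 to compound 2 (0.30 log units; within the scatter), swapped one group for another at this place and did not move the number beyond the scatter, so no step beyond the scatter is expected here either: a 1.1-fold higher number from compound 2 to compound 3 (0.04 log units; within the scatter). Compound 3 is therefore estimated at 22 nM, between 8 nM and 60 nM.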

Compound 3, half-maximal inhibitory concentration: 25.1 nM
For compound 3 the middle estimate is 1.1-fold (0.06 log units) below the measured one; measured number inside the range.
By their numbers in this assay, from the lowest: compounds 2, 3 and 1 (each within the scatter of the next).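

In this assay rearranging the same atoms, with ((methylcarbamoyl)methyl)amino in place of methyl(methylcarbamoyl)amino, gives a 1.3-fold higher number from compound 2 to compound 3 (0.10 log units; within the scatter) and so leaves the number within the scatter. Putting (methylcarbamoyl)methyl in place of (pyrazin-2-yl)carbonyl on the amine nitrogen gives a 1.6-fold lower number from compound 1 to compound 3 (0.20 log units; within the scatter) and also stays within it, so the three different groups at this place cannot be ranked. No measured evidence accounts for these numbers. On these data alone, whether a carboxylic acid or a longer chain at this place would move the number beyond the scatter remains open.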